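A few compounds are considered here, and "the series" means these few. Any claim that something is new, unique, unknown or untested is made for them only; others in the source may bear on it.

Measured in a functional assay on MDA-MB-231 cells (Homo sapiens) for cytotoxicity, with a stated time of 48 h; a higher number here means a weaker inhibitor, a lower number a stronger inhibitor:
- compound 1 `COc1cc(OC)c(C(=O)/C=C/c2ccccc2OC)c(OC)c1`: 13000 nM
- compound 2 `COc1cc(OC)c(C(=O)/C=C/c2ccccc2SC)c(OC)c1`: 9900 nM
- compound 3 `COc1cc(OC)c(C(=O)/C=C/c2ccc(F)cc2)c(OC)c1`: 10700 nM

Compound 3 is not separated from the other two measured compounds. All three steps among them lie within the scatter: a 1.2-fold lower number from compound 1 to compound 3 (0.08 log units; within the scatter), a 1.1-fold higher number from compound 2 to compound 3 (0.03 log units; within the scatter) and a 1.3-fold lower number from compound 1 to compound 2 (0.12 log units; within the scatter).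

Compound 4 `COc1cc(OC)c(C(=O)/C=C/c2ccc(Br)cc2)c(OC)c1` is the next to consider. It differs from compound 3 in one place: bromo in place of fluoro on an aromatic carbon. This puts bromo in place of fluoro on an aromatic carbon, para to a large group.

Among the compounds with values here, no measured step exchanges one halogen for another, so this change has no direct precedent here. The closest evidence is the two steps into compound 3 given above, both of which change the aromatic substituent and stay within the scatter. On that limited basis, no shift beyond the scatter is expected in this assay. The expected change is a 1.1-fold lower number from compound 3 to compound 4 (0.05 log units; within the scatter). For compound 4 the estimated value is 9500 nM, with an expected range from 5000 nM to 18000 nM.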

Compound 4, half-maximal inhibitory concentration: 11100 nM
The estimate for compound 4 lay 1.2-fold (0.07 log units) below the measured number; the range from low to high includes it.
By their numbers in this assay, from the lowest: compounds 2, 3, 4 and 1 (each within the scatter of the next).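

In this assay, the exchange of 4-fluorophenyl for 4-bromophenyl gives a 1.0-fold higher number from compound 3 to compound 4 (0.02 log units; within the scatter) and so does not separate bromo from fluoro at this place, on an aromatic carbon para to a large group. The changes of the whole aryl group read the same way, with a 1.1-fold higher number from compound 2 to compound 4 (0.05 log units; within the scatter) and a 1.2-fold lower number from compound 1 to compound 4 (0.07 log units; within the scatter) as the two steps, so each of the four compounds now stands within the scatter of the others. No supporting evidence bears on this result.

Still open, on these data alone, is whether an amine or a carboxylic acid on this aromatic carbon would give a number beyond the scatter of these four compounds. Since no step shown so far leaves the scatter, the series does not yet show which parts of the shared core, if any, govern the read-out.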